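Squalene Synthase Inhibitors: From Compound 3 to Compound 4

This account rests on a few compounds, and the source may have more. Where it says the series, first, only, none or still open, it means among the compounds named here.

Measured compounds:
Compound 1, `C=CCc1cc(C(=O)CCC)ccc1OCC(O)CNC(C)C`, 4.5 nM
Compound 2, `CC(C)NCCCOc1ccccc1Cc1ccccc1`, 12 nM
Compound 3, `C=CCc1cc(OC(=O)CC)ccc1OCCCNC(C)C`, 0.05 nM

In an assay for inhibition of squalene synthase (Rattus norvegicus), using microsomes (a higher number here means a weaker inhibitor, a lower number a stronger inhibitor), compound 3 gives the lowest number of the three, and both other compounds lie beyond the scatter from it. Compound 4, `C=CCc1cc(N)ccc1OCCCNC(C)C`, has not yet been measured. It differs from compound 3 in one place: amino in place of propanoyloxy on an aromatic carbon. Within the data shown here, no pair of measured compounds shares a single-point difference, so this change has no precedent among them. Given how low compound 3 stands, the account expects the loss of the propanoyloxy group in favour of amino to weaken inhibition, with a sizeable step up from compound 3 to compound 4 in this assay, expected as a 100-fold higher number from compound 3 to compound 4 (2.00 log units; beyond the scatter). Compound 4 is therefore estimated at 5 nM, within 0.5 nM to 50 nM.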

Compound 4, half-maximal inhibitory concentration: 250 nM
Estimate against measurement, compound 4: 50-fold (1.70 log units) below; measured number above the stated range.
By their numbers in this assay, from the lowest: compound 3; then compound 1; then compound 2; then compound 4.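

In this assay, among these compounds, amino in place of propanoyloxy gives a 5000-fold higher number from compound 3 to compound 4 (3.70 log units; beyond the scatter), the first single-point step in this set. This aromatic carbon, meta to an allyl group and para to a group of 8 heavy atoms, is therefore far from indifferent to what it carries, since this one change moves the number well beyond the scatter. Nothing available explains the size of this step. The compounds shown leave open which part of propanoyloxy matters, and how a hydroxyl, acetyloxy, butanoyloxy or propanamido group would compare at this carbon.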